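The source may report more compounds than this note shows. Statements on the series, on what has been measured and on what is new or still open speak of the compounds shown alone.

Measured compounds: compound 1 `CC(C(=O)NCc1ccc(C(F)(F)F)nc1-c1ccc(Cl)cc1)c1ccc(NS(C)(=O)=O)c(F)c1`, compound 2 `CC(C(=O)NCc1ccc(C(F)(F)F)nc1-c1ccc(F)c(Cl)c1)c1ccc(NS(C)(=O)=O)c(F)c1`, compound 3 `CC(C(=O)NCc1ccc(C(F)(F)F)nc1-c1ccsc1)c1ccc(NS(C)(=O)=O)c(F)c1`.

In an assay on CHO cells for antagonist activity at transient receptor potential cation channel subfamily V member 1 (Homo sapiens), read by FLIPR (on this read-out higher numbers stand for weaker inhibition and lower numbers for stronger inhibition), compound 1 gives 0.7 nM, compound 2 gives 0.2 nM, and compound 3 gives 2 nM, the highest of the three; the steps that lead to it are a 2.9-fold higher number from compound 1 to compound 3 (0.46 log units; beyond the scatter) and a 10-fold higher number from compound 2 to compound 3 (1.00 log units; beyond the scatter), both beyond the scatter.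

Compound 4 `CC(C(=O)NCc1ccc(C(F)(F)F)nc1/C=C/c1ccccc1)c1ccc(NS(C)(=O)=O)c(F)c1` differs from compound 3 by 2-phenylethenyl in place of thiophen-3-yl on an aromatic carbon. Both measured steps that bear on it, a 2.9-fold higher number from compound 1 to compound 3 (0.46 log units; beyond the scatter) and a 10-fold higher number from compound 2 to compound 3 (1.00 log units; beyond the scatter), show that a thiophen-3-yl at this position sits at the weak end, whereas a six-membered aromatic ring of carbon only gives lower numbers. Among the compounds with values here, the 2-phenylethenyl group brings such a ring, but through a double bond, for which no measured step exists, so only a modest change is expected: a 1.7-fold lower number from compound 3 to compound 4 (0.22 log units; within the scatter). Compound 4 is estimated at 1.2 nM, with a range of 0.3 nM to 5 nM.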

Compound 4, inhibition constant: 2.2 nM
Beside the measured number, compound 4's estimate is 1.8-fold (0.26 log units) below it; measured number inside the range.
By their numbers in this assay, from the lowest: compound 2; then compound 1; then compounds 3 and 4 (each within the scatter of the next).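

In this assay, 2-phenylethenyl and thiophen-3-yl cannot be told apart at this position next to the ring nitrogen, with a 1.1-fold higher number from compound 3 to compound 4 (0.04 log units; within the scatter). A six-membered aromatic ring of carbon only, when carried on a double bond, therefore does not match the directly attached substituted phenyl groups, with a 3.1-fold higher number from compound 1 to compound 4 (0.50 log units; beyond the scatter) and an 11-fold higher number from compound 2 to compound 4 (1.04 log units; beyond the scatter). Nothing available explains these steps.

The compounds shown leave open how a saturated 2-phenylethyl chain, or an amine such as morpholin-4-yl, would read at this position.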